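A few compounds are considered here, and "the series" means these few. Any claim that something is new, unique, unknown or untested is made for them only; others in the source may bear on it.

Measured so far in an ADME assay on HepG2 cells (Homo sapiens) for cytotoxicity, with a stated time of 3 days (on this read-out lower numbers stand for higher toxicity in this test and higher numbers for lower toxicity in this test), are three compounds. Compound 1 `CC(Sc1nnc(-c2ccncc2)s1)C(=O)Nc1ccccc1` gives > 50000 nM, which is a limit of the assay and not a number. Compound 2 `CC(Sc1nnc(-c2ccncc2)s1)C(=O)NCc1ccccc1` gives > 50000 nM, again a limit. Compound 3 `CC(CSc1nnc(-c2ccncc2)s1)C(=O)NCc1ccccc1` gives > 50000 nM, also a limit.

Compound 4 `CC(CSc1nnc(-c2ccncc2)s1)C(=O)Nc1ccccc1` has not yet been measured. It differs from compound 3 by phenyl in place of benzyl on an amide-type nitrogen. The same change was made between two measured compounds, from compound 2 to compound 1: phenyl in place of benzyl on an amide-type nitrogen. The place is the same in both pairs, so this is the same change, not merely the same kind. The step it made was a step that the two limits leave unreadable from compound 2 to compound 1, a result that follows from the limit of > 50000 nM in this assay, at which 3 of the 3 values shown sit. How the core of compound 2 differs from the core of compound 3 is not broken down here.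

Resting on (the limit of > 50000 nM in this assay, at which 3 of the 3 values shown sit), compound 4 is expected to sit at the limit as well, with an expected step that the limit leaves unreadable from compound 3 to compound 4. The estimate for compound 4 is 60000 nM, with a range from 20000 nM to 200000 nM.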

Compound 4, half-maximal cytotoxic concentration: > 50000 nM
Compound 4 ended at the assay's limit; the forecaster's own chance of this, stated with the estimate: 85%; the middle value is on the limit's open side.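

Going by these compounds alone, no step from compound 3 to compound 4 can be read in this assay, because both compounds sit at a limit of the assay and a limit is not a number: the limit of > 50000 nM in this assay, at which 4 of the 4 values shown sit. The compounds shown leave open whether phenyl in place of benzyl on an amide-type nitrogen changes this read-out at all.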